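A few compounds are considered here, and "the series" means these few. Any claim that something is new, unique, unknown or untested is made for them only; others in the source may bear on it.

In an ADME assay on HEK293 cells (Homo sapiens) for cytotoxicity, read by MTT assay, with a stated time of 48 h (a higher number here means a weaker inhibitor, a lower number a stronger inhibitor), compound 1 `CCn1c(N)c(-c2nc3ccccc3[nH]2)c2nc(C#N)c(C#N)nc21` gives > 50000 nM, which is a limit of the assay. Going by the values given here, compound 2 `CCN(CC)CCn1c(N)c(-c2nc3ccccc3[nH]2)c2nc(C#N)c(C#N)nc21` gives 12200 nM, the only actual number so far. Compound 3 `CN1CCN(CCn2c(N)c(-c3nc4ccccc4[nH]3)c3nc(C#N)c(C#N)nc32)CC1` differs from compound 2 by 4-methylpiperazin-1-yl in place of diethylamino on a saturated chain carbon, two bonds along the chain from an aromatic nitrogen, with 4-methylpiperazin-1-yl in place of diethylamino on the same chain carbon. Among the compounds with values here, the only measured step, an at least 4.0-fold lower number from compound 1 to compound 2 (0.61 log units; beyond the scatter), put diethylamino in place of hydrogen there, so it bears only loosely on exchanging one group for the other. No step beyond the scatter is therefore expected, the estimate being a 1.2-fold higher number from compound 2 to compound 3 (0.09 log units; within the scatter). Compound 3 is estimated at 15000 nM, with an expected range of 6000 nM to 40000 nM.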

Compound 3, half-maximal inhibitory concentration: 10900 nM
Estimate against measurement, compound 3: 1.4-fold (0.14 log units) above; the range from low to high includes it.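

In this assay the exchange of diethylamino for 4-methylpiperazin-1-yl brings a 1.1-fold lower number from compound 2 to compound 3 (0.05 log units; within the scatter) and so shows that an open amine and a ring amine on this chain carbon read alike. The ring amine also stands apart from hydrogen, with an at least 4.5-fold lower number from compound 1 to compound 3 (0.66 log units; beyond the scatter) as the step. Going by these compounds, compound 1 sits at a limit of the assay, so the full size of that step stays unknown: the limit of > 50000 nM in this assay, at which 1 of the 3 values shown sits. Still open, on these data alone, is whether a longer chain, a morpholine or a carboxylic acid at this place would read the same.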